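Extending the Amide Substituent: Compound 2 to Compound 4

The source may hold more compounds than are shown below. What is called first, only, known or untested is meant among the compounds shown, and "the series" means these compounds.

In a functional assay on A549 cells (Homo sapiens) for antiproliferative activity, read by CCK-8 assay, with a stated time of 72 h (a higher number here means a weaker inhibitor of growth, a lower number a stronger inhibitor of growth), compound 1 (`CC[C@@H]1C(=O)N(C)c2cnc(-n3ccc4cc(C(N)=O)ccc43)nc2N1C1CCCC1`) gives 4350 nM and compound 2 (`CC[C@@H]1C(=O)N(C)c2cnc(-n3ccc4cc(C(=O)NC(C)C)ccc43)nc2N1C1CCCC1`) gives 1780 nM, the lower of the two numbers available. Compound 3 (`CCC1C(=O)N(C)c2cnc(Nc3ccc(S(N)(=O)=O)cc3)nc2N1c1ccn(C)n1`) is recorded as "not active" (no number reported), so it offers no number for comparison.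

Compound 4 (`CC[C@@H]1C(=O)N(C)c2cnc(-n3ccc4cc(C(=O)NCC(C)C)ccc43)nc2N1C1CCCC1`) has not yet been measured. Its structure differs from that of compound 2 as follows: isobutyl in place of isopropyl on an amide-type nitrogen. In short, isobutyl stands in place of isopropyl on an amide-type nitrogen.

Among the measured compounds shown here, only one measured step bears on this change. It is a 2.4-fold lower number from compound 1 to compound 2 (0.39 log units; beyond the scatter), a modest step beyond the scatter, made when isopropyl replaced hydrogen on an amide-type nitrogen. For the measured compounds named here, one step sets no trend, and no measured compound carries isobutyl. Resting on that single step, only a small move towards a lower number is expected, possibly none beyond the scatter. The expected change is a 1.2-fold lower number from compound 2 to compound 4 (0.07 log units; within the scatter). For compound 4 the estimated value is 1500 nM, with an expected range of 700 nM to 3300 nM.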

Compound 4, concentration for 50% growth inhibition: 1730 nM
Compound 4: the middle estimate sits 1.2-fold (0.06 log units) below what was measured; the measured number falls inside the stated range.
By their numbers in this assay, from the lowest: compounds 4 and 2 (each within the scatter of the next); then compound 1.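

In this assay, isobutyl in place of isopropyl on the amide-type nitrogen gives a 1.0-fold lower number from compound 2 to compound 4 (0.01 log units; within the scatter), so one more carbon on this substituent does not separate the two compounds. Isobutyl in place of hydrogen on that nitrogen gives a 2.5-fold lower number from compound 1 to compound 4 (0.40 log units; beyond the scatter), which shows that the modest step seen earlier with isopropyl is not confined to that one group. No evidence shown here accounts for these results.

From the compounds shown here alone, whether a longer chain, or a chain ending in an amine or a carboxylic acid, would move the number further at this position remains open. The compounds shown also leave open whether these two alkyl groups would give similar numbers on a different core.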